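Swapping the aryl group on a fused oxygen core

The source may hold more compounds than are shown below. What is called first, only, known or untested is meant among the compounds shown, and "the series" means these compounds.

Measured compounds:
compound 1 `CCC1=C(O)c2c(oc(-c3ccc(Br)cc3)cc2=O)C(CC)(CC)C1=O`: 15.7 uM
compound 2 `CCC1=C(O)c2c(oc(-c3ccccc3C(F)(F)F)cc2=O)C(CC)(CC)C1=O`: 43.1 uM

In a functional assay on KBVIN cells (Homo sapiens) for antiproliferative activity, read by sulforhodamine B assay, with a stated time of 3 days (a lower number here means that less compound is needed, a higher number that more compound is needed for the effect), compound 1 gives 15.7 uM, the lowest of the two numbers. Compound 2 gives 43.1 uM, a higher number by a margin beyond the usual scatter. Compound 3 `CCC1=C(O)c2c(oc(-c3ccc(OC)c(F)c3)cc2=O)C(CC)(CC)C1=O` has not been measured. It differs from compound 1 in one place: 3-fluoro-4-methoxyphenyl in place of 4-bromophenyl on an aromatic carbon. Going by the values given here, no pair of measured compounds shows a change of this kind, so the size of the step cannot be read from the numbers. A small step is expected, near the scatter or slightly toward a higher number. Compound 3 is estimated at 20 uM, between 8 uM and 50 uM, a step of a 1.3-fold higher number from compound 1 to compound 3 (0.11 log units; within the scatter).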

Compound 3, concentration for half-maximal effect: 0.1 uM
The estimate for compound 3 lay 200-fold (2.30 log units) above the measured number; measured number below the stated range.
By their numbers in this assay, from the lowest: compound 3; then compound 1; then compound 2.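

Swapping 4-bromophenyl for 3-fluoro-4-methoxyphenyl on the shared core brings a 160-fold lower number from compound 1 to compound 3 (2.20 log units; beyond the scatter) in this assay and so shows that this aromatic carbon can govern the result strongly, far more than the two earlier numbers alone could reveal. Nothing measured here explains why this single change has so large an effect. The compounds shown leave open whether the methoxy group, the fluorine or the two together account for the step. Also open, from the compounds shown here alone, is how an ethoxy group or an amine would fare on that aryl ring.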